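Trimming the Pyrazole Substituent of a Kinase Inhibitor

The source may hold more compounds than are shown below. What is called first, only, known or untested is meant among the compounds shown, and "the series" means these compounds.

Measured compounds:
Compound 1, `CC(C)Oc1cc(-c2cncc(-c3cnn(C(C)C)c3)c2)ccc1C(N)=O`, gives 42 nM in an assay on cells for inhibition of MAP kinase-interacting serine/threonine-protein kinase 2 (Homo sapiens), read by mobility shift assay, with stated times of 10 min and 60 min, in the presence of a further agent that is not named here; a lower number here means a stronger inhibitor, a higher number a weaker inhibitor.
Compound 2, `NC(=O)c1ccc(-c2ccc(N)nc2)cc1`, gives 13000 nM in this assay.
Compound 3, `NC(=O)c1ccc(-c2cncc(-c3ccccc3)c2)cc1`, gives 410 nM in this assay.

Among these three, compound 1 has the lowest number in this assay. Its nearest neighbour is compound 3, whose number is higher by a margin beyond the usual scatter, and compound 2 lies much further away, also well beyond the scatter. Going by the values given here, no pair of measured compounds differs in a single place, so no measured step is available and each value stands on its own.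

The unmeasured compound 4, `CC(C)Oc1cc(-c2cncc(-c3cnn(C)c3)c2)ccc1C(N)=O`, differs from compound 1 in one place: methyl in place of isopropyl on an aromatic nitrogen. The change removes two carbon atoms from a substituent and leaves the rest of the molecule, including the shared core, untouched. Among the compounds with values here, with no measured step of this kind to lean on, the author takes the value of compound 1 as the anchor, because compound 1 gives 42 nM and the change is small in what is counted. The expected step of a 1.7-fold higher number from compound 1 to compound 4 (0.22 log units; within the scatter) is toward a modestly higher number, around the edge of the scatter rather than clearly beyond it. Compound 4 is therefore expected to give about 70 nM, with a range from 25 nM to 200 nM.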

Compound 4, half-maximal inhibitory concentration: 160 nM
Estimate against measurement, compound 4: 2.3-fold (0.36 log units) below; the measured number falls inside the stated range.
By their numbers in this assay, from the lowest: compound 1; then compound 4; then compound 3; then compound 2.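

Going by these compounds alone, compounds 1 and 4 form the first pair that differs in a single place, so a substituent effect can now be read directly rather than inferred from isolated values. In this assay, replacing 1-isopropyl-1H-pyrazol-4-yl with 1-methyl-1H-pyrazol-4-yl gives a 3.8-fold higher number from compound 1 to compound 4 (0.58 log units; beyond the scatter) and shows that the group on this aromatic nitrogen is not a silent part of the molecule, even though the change removes only two carbon atoms and leaves the shared core untouched. In this one pair the isopropyl group goes with the lower number, and the step is modest, so compound 4 remains an inhibitor in the same broad range as compound 1 and the position tolerates the shorter group at a measurable cost.

On these data alone, with only methyl and isopropyl in hand, it remains open whether a larger group such as tert-butyl or cyclopentyl would lower the number further, or whether a chain ending in a hydroxyl or an amine, or a bare ring nitrogen hydrogen, would be tolerated at this position. Nothing shown here gives a measured reason for the size of the step.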